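This account rests on a few compounds, and the source may have more. Where it says the series, first, only, none or still open, it means among the compounds named here.

In a functional assay on SK-BR-3 cells (Homo sapiens) for antiproliferative activity, read by MTT assay, with a stated time of 72 h (a lower number here means a stronger inhibitor, a higher number a weaker inhibitor), compound 1 `C/C=C1/[C@H](O[C@@H]2O[C@H](COC(C)=O)[C@@H](OC(C)=O)[C@H](OC(C)=O)[C@H]2OC(C)=O)OC=C(C(=O)OC)[C@H]1CC(=O)OCCC` gives 6600 nM. Compound 2 `C=C(C)CCOC(=O)C[C@@H]1C(C(=O)OC)=CO[C@@H](O[C@@H]2O[C@H](CO)[C@@H](O)[C@H](O)[C@H]2O)/C1=C/C` reaches only the limit of this assay, > 15000 nM, so no exact number is known for it. One of the two values shown therefore sits at the limit of > 15000 nM in this assay, at which 1 of the 2 values shown sits. Compound 3 `C/C=C1/[C@H](O[C@@H]2O[C@H](CO)[C@@H](O)[C@H](O)[C@H]2O)OC=C(C(=O)OC)[C@H]1CC(=O)OC` differs from compound 2 in one place: hydrogen in place of 2-methylprop-2-en-1-yl on a saturated chain carbon bound to an oxygen next to a carbonyl group. The expected step, a step that the limit leaves unreadable from compound 2 to compound 3, is judged small, not beyond the usual scatter, and the direction is uncertain. Compound 3 is expected to give about 20000 nM, within a range from 6000 nM to 60000 nM, and it may again come back only as a limit.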

Compound 3, half-maximal inhibitory concentration: > 15000 nM
Compound 3 gave a limit, no number; the forecaster's own chance of this, stated with the estimate: 60%; the middle value does not contradict the limit.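

No step can be read from compound 2 to compound 3, as each gave only a limit and no number: the limit of > 15000 nM in this assay, at which 2 of the 3 values shown sit.

From the compounds shown here alone, whether replacing 3-methylbut-3-en-1-yl with methyl changes activity at all, and how large any change might be, stays open.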